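Fluoro to chloro on the shared core: cytotoxicity notes

The compounds below may be only part of what the source reports. "The series", "measured", "known", "first", "only" and "open" are said of these compounds alone.

Measured in an ADME assay on Vero cells (Chlorocebus sabaeus) for cytotoxicity, read by MTT assay, with a stated time of 72 h; a higher number here means a weaker inhibitor, a lower number a stronger inhibitor:
compound 1 `COc1ccc(CNc2nc([N+](=O)[O-])nc(-c3ccco3)c2NC=O)cc1`: > 40 ug/mL (a limit)
compound 2 `COc1ccc(CNc2nc(F)nc(-c3ccco3)c2NC=O)cc1`: > 40 ug/mL (a limit)

Neither entry is a number. Compound 2 gives > 40 ug/mL, which is a limit, so its position can only be stated as the limit of > 40 ug/mL in this assay, at which 2 of the 2 values shown sit.

The next compound is compound 3 `COc1ccc(CNc2nc(Cl)nc(-c3ccco3)c2NC=O)cc1`, which carries chloro in place of fluoro on an aromatic carbon, between two ring nitrogen atoms: chloro in place of fluoro on an aromatic carbon. Among the measured compounds shown here, the only measured step that bears on this change is a step that the two limits leave unreadable from compound 1 to compound 2, also a replacement at this place on the core. It provides no size to carry over.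

The expectation therefore rests on the limit reached by compound 2 and compound 1, and no step beyond the scatter is expected in this assay, in either direction. The step of a number no higher from compound 2 to compound 3 (the limit leaves the size open) is the estimated one. For compound 3 the expected value is 40 ug/mL, with an estimated range from 20 ug/mL to 80 ug/mL. A report as a limit is expected to be the most likely outcome.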

Compound 3, half-maximal inhibitory concentration: > 40 ug/mL
Compound 3 was reported as a limit; the forecaster's own chance of this, stated with the estimate: 75%; the middle value sits exactly at the limit.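

No step can be read among compound 1, compound 2 and compound 3 in this assay, since each entry is a limit and not a number: the limit of > 40 ug/mL in this assay, at which 3 of the 3 values shown sit.

The compounds shown leave open whether nitro, fluoro and chloro on this aromatic carbon of the shared core differ at all in this assay, and how large any such difference would be.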